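Changing the Aryl Group on the Core Nitrogen

The compounds below may be only part of what the source reports. "The series", "measured", "known", "first", "only" and "open" are said of these compounds alone.

Compound 1 `CNC(=O)c1cc(Oc2ccc(NC(=O)c3cc4cccnc4n(-c4ccccc4F)c3=O)cc2)ccn1`: 610 nM in a functional assay on A549 cells (Homo sapiens) for antiproliferative activity, read by MTT assay, with a stated time of 72 h; on this read-out lower numbers stand for stronger inhibition and higher numbers for weaker inhibition
Compound 2 `CNC(=O)c1cc(Oc2ccc(NC(=O)c3cc4cccnc4n(-c4ccc(Br)cc4F)c3=O)cc2)ccn1`: 1420 nM
Compound 3 `CCNC(=O)c1cc(Oc2ccc(NC(=O)c3cc4cccnc4n(-c4ccccc4F)c3=O)cc2)ccn1`: 490 nM

Compound 3 gives the lowest of the three numbers, though its gap to compound 1, a 1.2-fold lower number from compound 1 to compound 3 (0.10 log units; within the scatter), sits within the scatter, so the two cannot be ranked against each other. Compound 2 stands clearly apart from both, the step of a 2.3-fold higher number from compound 1 to compound 2 (0.37 log units; beyond the scatter) lying beyond the scatter.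

Compound 4 `CCNC(=O)c1cc(Oc2ccc(NC(=O)c3cc4cccnc4n(-c4ccc(OC)cc4)c3=O)cc2)ccn1` has not yet been measured. It differs from compound 3 in one place: 4-methoxyphenyl in place of 2-fluorophenyl on an aromatic nitrogen. For the measured compounds named here, the only measured step that touches the same part of the molecule is a 2.3-fold higher number from compound 1 to compound 2 (0.37 log units; beyond the scatter), where a single substituent added to that aryl ring gave a modest rise in the number. The ethyl amide step, a 1.2-fold lower number from compound 1 to compound 3 (0.10 log units; within the scatter), concerns a different part and stayed within the scatter. Going by the values given here, no measured pair shows the fluorine removed or a methoxy group introduced, so the direction of the change in this assay cannot be fixed from the data. Given that substitution on this ring has so far pushed the number up, a modest rise is expected for compound 4, a 1.5-fold higher number from compound 3 to compound 4 (0.18 log units; within the scatter), with the estimate 750 nM and a range from 250 nM to 2200 nM.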

Compound 4, half-maximal inhibitory concentration: 2010 nM
Estimate against measurement, compound 4: 2.7-fold (0.43 log units) below, and the stated range covers the measured number.
By their numbers in this assay, from the lowest: compounds 3 and 1 (each within the scatter of the next); then compounds 2 and 4 (each within the scatter of the next).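

With the ethyl amide held constant, replacing 2-fluorophenyl with 4-methoxyphenyl on the aromatic nitrogen of the shared core gives a 4.1-fold higher number from compound 3 to compound 4 (0.61 log units; beyond the scatter) in this assay, a step beyond the scatter. This is the first change shown that removes the 2-fluorophenyl group itself rather than adding to it, and it shows that activity in this assay depends on the aryl group at this position. Among the compounds shown, both changes to this aryl group raise the number and none goes against that trend, but no measured property of either group accompanies the step, so the data offer no explanation for it.

This single step swaps two features at once, as the fluorine leaves and a methoxy group enters under a different name and position on the ring, so the compounds shown cannot separate the contribution of one from the other. Unsubstituted phenyl, 4-fluorophenyl and 2-methoxyphenyl groups on this nitrogen would each address that question, and their effect remains open here.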